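The compounds below may be only part of what the source reports. "The series", "measured", "known", "first", "only" and "open" are said of these compounds alone.

Compound 1 `CCCn1c(SCc2cc([N+](=O)[O-])ccc2OC)nc2cc(NC(=O)NC(C)(C)C)ccc21` is the starting point of the comparison. In an assay on isolated protein for inhibition of Gonadotropin-releasing hormone receptor (Rattus norvegicus) (a lower number here means a stronger inhibitor, a higher number a weaker inhibitor), compound 1 gives 120 nM, the lowest of the two numbers that have been measured. Its nearest neighbour is compound 2 `COCCn1c(SCc2cc([N+](=O)[O-])ccc2OC)nc2cc(NC(=O)NC(C)(C)C)ccc21`, which in this assay gives 280 nM. Going by the values given here, the only measured step is a 2.3-fold higher number from compound 1 to compound 2 (0.37 log units; beyond the scatter), a change on the chain attached to the aromatic nitrogen.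

The step to compound 3 `CCCn1c(SCc2cc([N+](=O)[O-])ccc2OC)nc2cc(NC(=O)NC(C)(C)C)cc(C(=O)NCc3cccnc3)c21` is of a different kind: ((pyridin-3-yl)methyl)carbamoyl in place of hydrogen on an aromatic carbon. Among the compounds with values here, none of the measured steps touches this position or this type of group, so the step from compound 1 to compound 2 offers no direct guide; it shows only that a modest change on the shared core moves the number by a modest amount. Within the data shown here, with no measured step bearing on the change, the expectation for compound 3 rests on the value of compound 1 alone, and the step from compound 1 to compound 3 is therefore expected to be a 1.2-fold lower number from compound 1 to compound 3 (0.08 log units; within the scatter). On that basis compound 3 is estimated to give 100 nM, with a range from 20 nM to 500 nM in this assay.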

Compound 3, half-maximal inhibitory concentration: 54 nM
Beside the measured number, compound 3's estimate is 1.9-fold (0.27 log units) above it, within the range that was stated.
By their numbers in this assay, from the lowest: compound 3; then compound 1; then compound 2.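

The aromatic carbon ortho to a fused ring, which carries only hydrogen in compound 1 and compound 2, proves able to take a large substituent in this assay: the ((pyridin-3-yl)methyl)carbamoyl group, with its 10 heavy atoms, gives a 2.2-fold lower number from compound 1 to compound 3 (0.35 log units; beyond the scatter) and does not lose ground. Going by these compounds alone, the direction differs from that of the only earlier step, made on the chain at the aromatic nitrogen, which gave a 2.3-fold higher number from compound 1 to compound 2 (0.37 log units; beyond the scatter) and so went the other way, each step being beyond the usual scatter. Nothing available here accounts for the lower number seen with this group.

The compounds shown leave open which part of the new group carries the change, since the pyridin-3-yl ring, the methylene link and the amide hydrogen all enter together, and a plain benzyl amide, a simple methyl amide or a carboxylic acid on this carbon would separate them. They also leave open whether the same group would lower the number on the methoxy-bearing chain of compound 2.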